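Notes on a shared core: propoxy to (methylsulfonyl)oxy

The compounds below may be only part of what the source reports. "The series", "measured", "known", "first", "only" and "open" are said of these compounds alone.

Measured so far in a functional assay on A549 cells (Homo sapiens) for cytotoxicity; a higher number here means that more compound is needed for the effect, a lower number that less compound is needed:
compound 1 `Oc1ccc2nc(-c3ccccc3)cc(O)c2c1` gives 8.14 ug/mL
compound 2 `Oc1cc(-c2ccccc2)nc2ccc(Cl)cc12` gives 0.51 ug/mL
compound 3 `CCCOc1cc(-c2ccccc2)nc2ccccc12` gives > 10 ug/mL

Of the compounds shown here, three on the shared core have been measured. Within the data shown here, the only step between two compounds that differ in a single place is a 16-fold lower number from compound 1 to compound 2 (1.20 log units; beyond the scatter), a change of a substituent on the core itself.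

Compound 3 stands apart from the other two: in this assay compound 3 gives > 10 ug/mL, which is a limit of the assay and not a number (the limit of > 10 ug/mL in this assay, at which 1 of the 3 values shown sits).

Compound 4 `CS(=O)(=O)Oc1cc(-c2ccccc2)nc2ccccc12` differs from compound 3 in one place: methylsulfonyl in place of propyl on an oxygen on an aromatic ring.

Among the measured compounds shown here, no measured step bears on this change; the step of a 16-fold lower number from compound 1 to compound 2 (1.20 log units; beyond the scatter) concerns a different part of the molecule and gives no guide to swapping the group on the oxygen. With compound 3 at a limit, the expected step of an at least 1.2-fold lower number from compound 3 to compound 4 (0.09 log units; that floor lies within the scatter) is therefore small and uncertain in direction. Compound 4 is estimated at 8 ug/mL, with a range from 2 ug/mL to 30 ug/mL, and a limit rather than a number is again quite possible.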

Compound 4, half-maximal effective concentration: 6.21 ug/mL
Compound 4: the middle estimate sits 1.3-fold (0.11 log units) above what was measured, and the stated range covers the measured number.
By their numbers in this assay, from the lowest: compound 2; then compounds 4 and 1 (each within the scatter of the next). At a limit, above all of these: compound 3.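

Among these compounds, replacing propoxy with (methylsulfonyl)oxy gives the first reading on the group at this oxygen in this assay, with an at least 1.6-fold lower number from compound 3 to compound 4 (0.20 log units; that floor lies within the scatter) as the only step there. Compound 4 gives a number on the shared core, whereas compound 3 gives only a limit of the assay. The true size of the step cannot be read, because the value of compound 3 is a limit: the limit of > 10 ug/mL in this assay, at which 1 of the 4 values shown sits.

The compounds shown leave open how other groups on this oxygen would read, such as methyl, acetyl or a longer chain ending in an amine. They also leave open whether chloro on the core, as in compound 2, would keep its step with methylsulfonyl on this oxygen.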